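Heteroaryl amides: the step from compound 3 to compound 4

The compounds below may be only part of what the source reports. "The series", "measured", "known", "first", "only" and "open" are said of these compounds alone.

- compound 1 `CCCCCCCCCCCC[C@@H](O)[C@H]1CC[C@H]([C@H](O)CCCCCCCCCCNC(=O)c2cccs2)O1`: 3240 nM
- compound 2 `CCCCCCCCCCCC[C@@H](O)[C@H]1CC[C@H]([C@H](O)CCCCCCCCCCNC(=O)c2ccoc2)O1`: 100000 nM
- compound 3 `CCCCCCCCCCCC[C@@H](O)[C@H]1CC[C@H]([C@H](O)CCCCCCCCCCNC(=O)c2cncs2)O1`: 100000 nM

In a functional assay on HBC5 cells (Homo sapiens) for inhibition, read by colorimetric assay and sulforhodamine B assay, with a stated time of 48 h (on this read-out higher numbers stand for weaker inhibition of growth and lower numbers for stronger inhibition of growth), compound 3 gives 100000 nM, level with compound 2 and together with it the highest of the three numbers: no change at the digits printed from compound 2 to compound 3 (within the scatter). Compound 4 `CCCCCCCCCCCC[C@@H](O)[C@H]1CC[C@H]([C@H](O)CCCCCCCCCCNC(=O)c2ccsc2)O1` carries thiophen-3-yl in place of 1,3-thiazol-5-yl on a carbonyl carbon. The nearest measured match for the entering group is the thiophen-2-yl of compound 1. Two large steps lead away from it: a 31-fold higher number from compound 1 to compound 3 (1.49 log units; beyond the scatter), and a 31-fold higher number from compound 1 to compound 2 (1.49 log units; beyond the scatter). Going by the values given here, no measured compound carries thiophen-3-yl, so the reading is uncertain. A large expected step towards a lower number in this assay is a 33-fold lower number from compound 3 to compound 4 (1.52 log units; beyond the scatter). The estimate for compound 4 is 3000 nM, with an expected range of 500 nM to 25000 nM.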

Compound 4, concentration for 50% growth inhibition: 2090 nM
For compound 4 the middle estimate is 1.4-fold (0.16 log units) above the measured one; low and high end bracket the measured number.
By their numbers in this assay, from the lowest: compounds 4 and 1 (each within the scatter of the next); then compounds 2 and 3 (each within the scatter of the next).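

Thiophen-3-yl on the carbonyl carbon is far better tolerated than the 1,3-thiazol-5-yl (a 48-fold lower number from compound 3 to compound 4 (1.68 log units; beyond the scatter)) or furan-3-yl (a 48-fold lower number from compound 2 to compound 4 (1.68 log units; beyond the scatter)) groups. Thiophen-3-yl and thiophen-2-yl cannot be told apart at this position (a 1.6-fold lower number from compound 1 to compound 4 (0.19 log units; within the scatter)), so the point of attachment on the thiophene ring makes no readable difference here. The two thiophene amides therefore stand together, well apart from the furan and thiazole amides.

Nothing available explains this gap. As far as these compounds go, how a phenyl or pyridin-3-yl group on the carbonyl carbon would read remains open.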